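The source may report more compounds than this note shows. Statements on the series, on what has been measured and on what is new or still open speak of the compounds shown alone.

Compound 2 `Nc1nc(N)c2nc(O)n(Cc3ccccc3)c2n1` carries the shared core, while compound 1 `CCCCCSc1nc(N)c2nc(O)n(Cc3ccccc3)c2n1` has a pentylsulfanyl where compound 2 has an amino. In a functional assay (spleen, spleen) for activation, with Mus musculus as the target (a lower number here means that less compound is needed, a higher number that more compound is needed for the effect), compound 1 gives 10 uM, and compound 2 gives 10 uM. Within the data shown here, the one measured step, from compound 1 to compound 2, showed no change at the digits printed from compound 1 to compound 2 (within the scatter), so compound 2 stands level with compound 1. Compound 3 `CCCCNc1nc(N)c2nc(O)n(Cc3ccccc3)c2n1` differs from compound 2 by butyl in place of hydrogen on a nitrogen on an aromatic ring. Among the measured compounds shown here, that single step is the only guide, and it moved nothing, so the expected step here is no change at the digits printed from compound 2 to compound 3 (within the scatter). Compound 3 is therefore estimated at 10 uM, with a range from 3 uM to 30 uM.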

Compound 3, minimum effective concentration: 1 uM
Estimate against measurement, compound 3: 10-fold (1.00 log units) above, outside the stated range (below it).
By their numbers in this assay, from the lowest: compound 3; then compounds 1 and 2 (each within the scatter of the next).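

In this assay this position proves sensitive to what it carries: butyl on the amino nitrogen gives a 10-fold lower number from compound 2 to compound 3 (1.00 log units; beyond the scatter), whereas swapping pentylsulfanyl for amino had moved nothing. Butylamino in place of pentylsulfanyl gives a 10-fold lower number from compound 1 to compound 3 (1.00 log units; beyond the scatter), so having a chain there does not alone set the number. Nothing measured here explains these differences.

Still open, as far as these compounds go, is whether the linking atom or the chain length matters in that second step, which pentylamino would help separate. Also open, from the compounds shown here alone, is how methyl or hexyl on that nitrogen would compare with butyl.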